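Pyridin-2-yl replacing 3-methoxyphenyl on an orexin-2 antagonist

The source may report more compounds than this note shows. Statements on the series, on what has been measured and on what is new or still open speak of the compounds shown alone.

Measured so far:
compound 1, `COc1ccccc1C(C)NC(=O)COc1cc(C(F)(F)F)c2c(-c3ccccc3)nn(C)c2n1`: 158 nM
compound 2, `COc1cccc(C(C)NC(=O)COc2cc(C(F)(F)F)c3c(-c4ccccc4)nn(C)c3n2)c1`: 26 nM

In a functional assay on isolated protein for antagonist activity at Orexin receptor type 2 (Homo sapiens), read by fluorescence, FLIPR and calcium flux, with a stated time of 1 h (on this read-out higher numbers stand for weaker inhibition and lower numbers for stronger inhibition), compound 2 gives the lower of the two numbers, and a 6.1-fold lower number from compound 1 to compound 2 (0.78 log units; beyond the scatter). Compound 3, `CC(NC(=O)COc1cc(C(F)(F)F)c2c(-c3ccccc3)nn(C)c2n1)c1ccccn1`, carries pyridin-2-yl in place of 3-methoxyphenyl on a saturated chain carbon bound to an amide-type nitrogen and a saturated chain carbon. No measured step bears directly on this change, since the one step shown only moves the methoxy group within a phenyl ring; with compound 3 the methoxy group is gone altogether. The expectation is therefore a weaker result, a 3.8-fold higher number from compound 2 to compound 3 (0.59 log units; beyond the scatter). Compound 3 is estimated at 100 nM, within 25 nM to 400 nM.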

Compound 3, inhibition constant: "not active" (no number reported)
Nothing numeric was reported for compound 3, so the estimate cannot be set against anything.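

Compound 3 is reported as not active, with no number, so no step from compound 2 to compound 3 can be read, and nothing available explains this result. The compounds shown leave open whether the pyridin-2-yl ring itself or the absence of the methoxy group accounts for it.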